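Working notes on hepatocyte clearance, compound 3 to compound 4

The compounds below may be only part of what the source reports. "The series", "measured", "known", "first", "only" and "open" are said of these compounds alone.

Measured compounds:
Compound 1, `C[C@H](Nc1c(NCCCCCC(=O)NO)c(=O)c1=O)c1ccccc1`: in an ADME assay on cells (Hepatocyte, Homo sapiens) for pharmacokinetics, read by LC-MS, with a stated time of 90 min, tested at 1 uM (on this read-out lower numbers stand for slow clearance and higher numbers for fast clearance), compound 1 gives < 5 uL/min, which is a limit of the assay.
Compound 2, `O=C(CCCCCNc1c(NC2CCCCC2)c(=O)c1=O)NO`: in this assay compound 2 gives < 5 uL/min, also a limit.
Compound 3, `Cc1ccccc1Nc1c(NCCCCCC(=O)NO)c(=O)c1=O`: in this assay compound 3 gives < 5 uL/min, again a limit.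

Compound 3 therefore stands at the floor of what this assay reports, and it shares that position with both other compounds: the limit of < 5 uL/min in this assay, at which 3 of the 3 values shown sit. Going by the values given here, the steps a step that the two limits leave unreadable from compound 1 to compound 3 and a step that the two limits leave unreadable from compound 2 to compound 3 are accordingly unreadable, as is a step that the two limits leave unreadable from compound 1 to compound 2; no measured step gives a size for any change at this nitrogen.

Compound 4, `Cc1ccc(Nc2c(NCCCCCC(=O)NO)c(=O)c2=O)cc1`, differs from compound 3 by 4-methylphenyl in place of 2-methylphenyl on a nitrogen on an aromatic ring. Among the compounds with values here, nothing among the measured steps bears readably on this change, so the expectation is no step beyond the scatter, and compound 4 is expected to sit at the same limit. The step from compound 3 is estimated as a step that the limit leaves unreadable from compound 3 to compound 4. For compound 4 in this assay the estimate is 3 uL/min, with a range from 1 uL/min to 8 uL/min.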

Compound 4, intrinsic clearance in a liver preparation (reported as CLH), per the amount of preparation that the assay uses: 7.2 uL/min
Estimate against measurement, compound 4: 2.4-fold (0.38 log units) below; measured number inside the range.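

In this assay, going by these compounds alone, compound 4 gives 7.2 uL/min and is the only one of the four compounds with a number rather than a limit, so this nitrogen now carries one group with a readable value. The change reads as an at least 1.4-fold higher number from compound 3 to compound 4 (0.15 log units; that floor lies within the scatter) and is matched by an at least 1.4-fold higher number from compound 2 to compound 4 (0.15 log units; that floor lies within the scatter) and an at least 1.4-fold higher number from compound 1 to compound 4 (0.15 log units; that floor lies within the scatter) in the other two steps, so 4-methylphenyl is not shown to shift clearance beyond the scatter. The steps among compound 1, compound 2 and compound 3 stay unreadable, and each new step gives only a floor: the limit of < 5 uL/min in this assay, at which 3 of the 4 values shown sit.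

Going by these compounds, the true size of each step remains open. Also open, on these data alone, is whether a plain phenyl or a 4-chlorophenyl on this nitrogen would give a number or stay at the limit.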